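Replacing the pentamethylphenyl group of compound 2

The source may hold more compounds than are shown below. What is called first, only, known or untested is meant among the compounds shown, and "the series" means these compounds.

Going by the values given here, in a physicochemical assay for permeability, using PAMPA (on this read-out higher numbers stand for higher permeability and lower numbers for lower permeability), compound 1 `CC[C@@H]1C[C@H](CC)CN(CCCNC(=O)C2CCN(Cc3nc(-c4ccccc4C)oc3C)CC2)C1` gives 1270 10^-6 cm/s and compound 2 `Cc1oc(-c2c(C)c(C)c(C)c(C)c2C)nc1CN1CCC(C(=O)NCCCN2C[C@H](C)C[C@H](C)C2)CC1` gives 455 10^-6 cm/s as the only numbers so far. Compound 2 is the lower of the two, and its gap to compound 1 lies beyond the usual scatter. Among the compounds with values here, these two compounds differ in more than one place, so no single-change step is available as a guide.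

Compound 3 `Cc1oc(-c2c(F)cccc2F)nc1CN1CCC(C(=O)NCCCN2C[C@H](C)C[C@H](C)C2)CC1` has 2,6-difluorophenyl in place of 2,3,4,5,6-pentamethylphenyl on an aromatic carbon, as counted in 2,6-difluorophenyl in place of 2,3,4,5,6-pentamethylphenyl on an aromatic carbon for the exchange. The group sits next to the ring nitrogen and next to the ring oxygen of a five-membered aromatic ring.

Within the data shown here, no measured example of this exchange exists. The expectation in this assay is therefore no step beyond the scatter in either direction, and it rests only on compound 2 at 455 10^-6 cm/s as the starting value. The estimated change is a 1.1-fold lower number from compound 2 to compound 3 (0.03 log units; within the scatter) as a working figure. Compound 3 is expected at 420 10^-6 cm/s with an estimated range from 150 10^-6 cm/s to 1100 10^-6 cm/s for now.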

Compound 3, apparent permeability: 82.4 10^-6 cm/s
The estimate for compound 3 lay 5.1-fold (0.71 log units) above the measured number; the whole stated range lies above it.
By their numbers in this assay, from the lowest: compound 3; then compound 2; then compound 1.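

In this assay, going by these compounds alone, putting 2,6-difluorophenyl in place of 2,3,4,5,6-pentamethylphenyl gives a 5.5-fold lower number from compound 2 to compound 3 (0.74 log units; beyond the scatter), the first single-change step, so the group on this aromatic carbon of the five-membered aromatic ring does move the read-out. The leaving and entering groups have the same counts of one six-membered aromatic ring of carbon only, 0 hydrogen-bond donors, 0 hydrogen-bond acceptors and no net charge, so a step beyond the scatter occurs with these counts unchanged, while the group goes from 11 heavy atoms to 8 and gains fluorine. No measurement at hand accounts for the size or direction of this step.

A single exchange that removes five methyl groups and adds two fluorine atoms cannot separate the contribution of either, and it leaves open whether a similar step would appear with the side chain of compound 1. An unsubstituted phenyl group and a 2,6-dimethylphenyl group at the same place, each compared directly with compound 2 and compound 3, would begin to divide the exchange into its parts.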